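A few compounds are considered here, and "the series" means these few. Any claim that something is new, unique, unknown or untested is made for them only; others in the source may bear on it.

Measured in a physicochemical assay for solubility; a lower number here means a less soluble compound, a higher number a more soluble compound:
- compound 1 `COc1ccc(-n2cnc3cnc(-c4ccc(F)cc4C)cc32)cc1OC`: > 200000 nM (a limit of the assay, not a number)
- compound 2 `COc1ccc(-n2cnc3cnc(-c4ccc(F)cc4C)cc32)cc1`: 117000 nM
- compound 3 `CCOc1ccc(-n2cnc3cnc(-c4ccc(F)cc4C)cc32)cc1`: 12000 nM

Compound 2 holds the higher of the two actual numbers. Compound 4 `COc1ccc(-n2cnc3cnc(-c4ccc(F)cc4C)cc32)cn1` carries 6-methoxypyridin-3-yl in place of 4-methoxyphenyl on an aromatic nitrogen. Two measured steps change this same group: an at least 1.7-fold lower number from compound 1 to compound 2 (0.23 log units; that floor lies within the scatter), and a 9.8-fold lower number from compound 2 to compound 3 (0.99 log units; beyond the scatter). Neither exchanges a ring carbon for a ring nitrogen, so both bear on the change only loosely. In this assay, the expected result is no shift beyond the scatter: a 1.0-fold higher number from compound 2 to compound 4 (0.01 log units; within the scatter). The estimate for compound 4 is 120000 nM, with an expected range from 45000 nM to 200000 nM.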

Compound 4, solubility: > 200000 nM
Compound 4: only a limit was reported; the forecaster's own chance of this, stated with the estimate: 25%; at least 1.6-fold (0.22 log units) between middle value and limit.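

In this assay, 6-methoxypyridin-3-yl in place of 4-methoxyphenyl on the aromatic nitrogen gives an at least 1.7-fold higher number from compound 2 to compound 4 (0.23 log units; that floor lies within the scatter), the first ring carbon to ring nitrogen exchange seen at this position. Compound 4 gives > 200000 nM, a limit of the assay and not a number. The full size of the step therefore stays hidden, and compound 1 and compound 4 cannot be ordered: the limit of > 200000 nM in this assay, at which 2 of the 4 values shown sit.

As far as these compounds go, it remains open whether the same exchange would raise the lower number of compound 3. Also open, from the compounds shown here alone, is how an amine or a carboxylic acid in place of the methoxy on this ring would read in this assay.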